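A tert-Butyl Amide in Place of a Fluorobenzyl Amide

The compounds below may be only part of what the source reports. "The series", "measured", "known", "first", "only" and "open" are said of these compounds alone.

Compound 1 `C=CC1=C(C(=O)NCc2ccccc2F)C(c2ccc(F)cc2)OC1` carries a 2-fluorobenzyl group on its amide nitrogen. Among the measured compounds shown here, in a functional assay on QGY7701 cells (Homo sapiens) for cytotoxicity, read by MTT assay, with a stated time of 24 h (a lower number here means a stronger inhibitor, a higher number a weaker inhibitor), compound 1 gives 51400 nM, the only plain number available in this set, so it stands as a weak inhibitor with nothing stronger to compare against. Compound 2 `C=CC1=C(C(=O)NCc2ccccc2)C(c2ccc(OC)cc2)OC1` is a close relative with a plain benzyl group and a methoxy-bearing aryl ring. In this assay compound 2 reaches only > 100000 nM, which is a limit of the assay and not a number; it sits at the limit of > 100000 nM in this assay, at which 1 of the 2 values shown sits.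

Compound 3 `C=CC1=C(C(=O)NC(C)(C)C)C(c2ccc(F)cc2)OC1` differs from compound 1 in one place: tert-butyl in place of 2-fluorobenzyl on an amide-type nitrogen. For the measured compounds named here, no measured pair shows what such a swap does in this assay. Without that guide, the expected step in this assay is a 1.4-fold higher number from compound 1 to compound 3 (0.13 log units; within the scatter), small, within the usual scatter or leaning towards weaker inhibition. Compound 3 is therefore estimated at 70000 nM in this assay, with a likely range from 25000 nM to 200000 nM.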

Compound 3, half-maximal inhibitory concentration: > 100000 nM
Compound 3 gave a limit, no number; the forecaster's own chance of this, stated with the estimate: 35%; middle value at least 1.4-fold (0.15 log units) from the limit.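

In this assay, putting tert-butyl in place of 2-fluorobenzyl on the amide-type nitrogen, with the rest of compound 1 unchanged, gives an at least 1.9-fold higher number from compound 1 to compound 3 (0.28 log units; that floor lies within the scatter). The result for compound 3 is a limit of the assay and not a number, and such limits now make up most of this small set: the limit of > 100000 nM in this assay, at which 2 of the 3 values shown sit. Going by these compounds, this single change therefore removes the aromatic ring from this position without revealing any stronger inhibition, but only a floor for the step can be read, and its true size remains unknown.

On these data alone, it remains open whether a chain ending in an amine or a carboxylic acid on this nitrogen would bring the number down. Also open, as far as these compounds go, is what a plain benzyl group would give on the core of compound 1.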